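A few compounds are considered here, and "the series" means these few. Any claim that something is new, unique, unknown or untested is made for them only; others in the source may bear on it.

Compound 1 `CC(C)(C)OC(=O)/C=C1/C(=O)Nc2ccccc21` is the parent of this small set. In a toxicity assay on L02 cells (Homo sapiens) for cytotoxicity, read by CCK-8 assay, with a stated time of 72 h (on this read-out higher numbers stand for weaker inhibition and lower numbers for stronger inhibition), compound 1 gives 2450 nM, the lowest of the three numbers measured, though each of the other two lies within the usual scatter of it. Compound 2 `COc1ccc2c(c1)/C(=C\C(=O)OC(C)(C)C)C(=O)N2` gives 3820 nM in this assay, and compound 3 `CC(C)(C)OC(=O)/C=C1/C(=O)Nc2ccc(Cl)cc21` gives 4720 nM. The step from compound 1 to compound 2 was a 1.6-fold higher number from compound 1 to compound 2 (0.19 log units; within the scatter), the step from compound 1 to compound 3 was a 1.9-fold higher number from compound 1 to compound 3 (0.28 log units; within the scatter), and compound 2 and compound 3 differ by a 1.2-fold higher number from compound 2 to compound 3 (0.09 log units; within the scatter).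

Compound 4 `CC(C)(C)OC(=O)/C=C1/C(=O)Nc2c(Cl)cccc21` differs from compound 1 by chloro in place of hydrogen on an aromatic carbon, the chloro entering on an aromatic carbon of a six-membered aromatic ring of carbon only, part of a fused system of two rings, ortho to a fused ring. The closest guide is the step from compound 1 to compound 3, which also put chloro in place of hydrogen on an aromatic carbon and which stayed within the scatter. The step from compound 1 to compound 4 in this assay is therefore expected to be a 1.4-fold higher number from compound 1 to compound 4 (0.15 log units; within the scatter), no larger than the scatter. Compound 4 is estimated at 3500 nM, with a range from 1500 nM to 8000 nM.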

Compound 4, half-maximal inhibitory concentration: 4800 nM
Beside the measured number, compound 4's estimate is 1.4-fold (0.14 log units) below it; low and high end bracket the measured number.
By their numbers in this assay, from the lowest: compounds 1, 2, 3 and 4 (each within the scatter of the next).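

In this assay, chloro in place of hydrogen at this position, on the aromatic carbon ortho to a fused ring, gives a 2.0-fold higher number from compound 1 to compound 4 (0.29 log units; within the scatter) and so stays within the scatter, as the chloro of compound 3 did at its own place on the core of compound 1. Compound 3 gives 4720 nM and compound 4 gives 4800 nM in this read-out, so these values do not separate the two chloro placements. No supporting measurement bears on this result.

The compounds shown leave open whether another group at this position, such as an amine, a carboxylic acid or a longer chain, would also stay within the scatter of compound 1. On these data alone, whether any change at this position can move the number beyond the scatter also remains open.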